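Removing the Methylene Linker: Expected Microsomal Half-Life

This account rests on a few compounds, and the source may have more. Where it says the series, first, only, none or still open, it means among the compounds named here.

Measured compounds:
Compound 1 `CC(C)[C@H](C[C@H]1OC(=O)NC1=O)c1ccc(-c2ccc3cccc(F)c3c2)[nH]c1=O`: 1.68 h
Compound 2 `Cc1cc(C(/C=C2\OC(=O)NC2=O)C(C)C)c(=O)[nH]c1-c1ccc2cccc(F)c2c1`: > 3 h
Compound 3 `O=C1NC(=O)/C(=C/C(c2ccc(-c3ccc4cccc(F)c4c3)[nH]c2=O)C2CCCCC2)O1`: 1.09 h

In an ADME assay on microsomes from liver (Homo sapiens) for metabolic stability (a higher number here means that the compound lasts longer, a lower number that the compound disappears faster), compound 1 gives 1.68 h. Compound 2 reached the limit of the assay rather than a number, namely (the limit of > 3 h in this assay, at which 1 of the 3 values shown sits). Compound 3, with 1.09 h, is the nearest to compound 1 among the numbers given; although compound 1 sits at the top of the two numbers, the gap to compound 3 is within the usual scatter, so the two cannot be told apart.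

Compound 4 `CC(C)[C@@H](c1ccc(-c2ccc3cccc(F)c3c2)[nH]c1=O)[C@@H]1OC(=O)NC1=O` has not yet been measured in this assay. It differs from compound 1 in one place: 2,4-dioxo-1,3-oxazolidin-5-yl in place of (2,4-dioxo-1,3-oxazolidin-5-yl)methyl on a saturated chain carbon bound to an aromatic carbon and a saturated chain carbon. The ring that enters is the same as the one that leaves, only the methylene that linked it to the chain is gone. Among the measured compounds shown here, no measured pair in this set probes this kind of change, so the direction is open. The step from compound 1 to compound 4 is expected to be a 1.0-fold higher number from compound 1 to compound 4 (0.01 log units; within the scatter), that is, no change beyond the scatter. Compound 4 is therefore estimated at 1.7 h, within a range from 0.85 h to 3.2 h.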

Compound 4, half-life: > 3 h
Compound 4 was reported as a limit; the forecaster's own chance of this, stated with the estimate: 20%; at least 1.7-fold (0.24 log units) between middle value and limit.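

In this assay, taking out the methylene that linked the 2,4-dioxo-1,3-oxazolidin-5-yl ring to the saturated chain carbon gives the first step read at this position: an at least 1.7-fold higher number from compound 1 to compound 4 (0.25 log units; that floor lies within the scatter). Going by these compounds, that figure is only a floor, so the true size of the step remains unknown, but the shorter link shows no sign of shortening the half-life. The result for compound 4 is a limit of the assay rather than a number, and such limits now make up a large share of the set: the limit of > 3 h in this assay, at which 2 of the 4 values shown sit.

On these data alone, how far compound 4 lies past that limit remains open. Also open, as far as these compounds go, is what this assay would show for a longer chain, such as ethylene, at this place, or for an amine or a carboxylic acid in place of the ring.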